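Swapping Chloro for Phenyl on a Weak Inhibitor

A few compounds are considered here, and "the series" means these few. Any claim that something is new, unique, unknown or untested is made for them only; others in the source may bear on it.

Going by the values given here, compound 2 `C=C[C@@H]1OC(c2ccc(Cl)cc2)=N[C@H]1CO` is the only compound here with a measured number in an assay on isolated protein for inhibition of matrix metalloproteinase-9 (Homo sapiens) (on this read-out higher numbers stand for weaker inhibition and lower numbers for stronger inhibition), where compound 2 gives 33000 nM. Compound 1 `C=C[C@@H]1OC(c2ccc(Cl)cc2)=N[C@H]1S` differs from it only in carrying sulfanyl on the saturated ring carbon where compound 2 has hydroxymethyl. In this assay compound 1 gives > 100000 nM, which is a limit of the assay rather than a number (the limit of > 100000 nM in this assay, at which 1 of the 2 values shown sits). Among the compounds with values here, the one measured step, an at least 3.0-fold lower number from compound 1 to compound 2 (0.48 log units; beyond the scatter), therefore shows compound 2 as the stronger of the two, while the full size of that step stays open.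

Compound 3 `C=C[C@@H]1OC(c2ccc(-c3ccccc3)cc2)=N[C@H]1CO` differs from compound 2 at a different place: phenyl in place of chloro on an aromatic carbon. Within the data shown here, no measured step touches this aromatic carbon, so the single known step gives no guide to the direction or size of this change. The expected step from compound 2 to compound 3 in this assay is therefore small, a 1.7-fold lower number from compound 2 to compound 3 (0.22 log units; within the scatter), with wide uncertainty. Compound 3 is expected to give about 20000 nM in this assay, within a range from 4000 nM to 100000 nM.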

Compound 3, inhibition constant: 24000 nM
Compound 3: middle estimate off by 1.2-fold (0.08 log units), on the low side, and the stated range covers the measured number.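

In this assay, replacing chloro with phenyl on this aromatic carbon gives a 1.4-fold lower number from compound 2 to compound 3 (0.14 log units; within the scatter), so this change, which adds a whole six-membered aromatic ring, leaves compound 2 and compound 3 indistinguishable. The earlier step concerned only the saturated ring carbon, whereas this pair gives the first view of the aromatic position: for these two compounds, the read-out does not separate 6 carbon atoms from 1 chlorine atom at this place. Compound 2 and compound 3 both give true numbers, and the only value that is a limit of the assay rather than a number belongs to compound 1: the limit of > 100000 nM in this assay, at which 1 of the 3 values shown sits.

The compounds shown carry only chloro or phenyl on this aromatic carbon, so what an amine or a carboxylic acid at the same place would do to the number remains open. Also open, as far as these compounds go, is whether phenyl would still match chloro if the hydroxymethyl on the saturated ring carbon gave way to a longer chain, such as hydroxypropyl.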